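Chloro for fluoro on two related cores

The source may report more compounds than this note shows. Statements on the series, on what has been measured and on what is new or still open speak of the compounds shown alone.

Measured compounds:
Compound 1, `Cc1oc2c([C@H]3CCN(C)C[C@H]3O)c(O)cc(O)c2c(=O)c1C(O)c1c(Cl)cccc1Cl`: 0%
Compound 2, `Cc1oc2c([C@H]3CCN(C)C[C@H]3O)c(O)cc(O)c2c(=O)c1C(O)c1c(F)cccc1Cl`: 0%
Compound 3, `CN1CC[C@H](c2c(O)cc(O)c3c(=O)cc(/C=C/c4ccccc4F)oc23)[C@H](O)C1`: 25%

In a functional assay on PC-3 cells (Homo sapiens) for inhibition, read by MTT assay, with a stated time of 48 h, tested at 10 uM (a lower number here means less inhibition of growth, a higher number more inhibition of growth at the concentration tested), compound 1 gives 0% and compound 2 gives 0%. The two differ only by chloro in place of fluoro on an aromatic carbon, and the step of no change at the digits printed from compound 2 to compound 1 (within the scatter) shows that this exchange left the read-out where it was. Compound 3 stands apart: in this assay compound 3 gives 25%, the highest of the three numbers, and its gap to compound 1 and to compound 2 lies beyond the scatter. How the core of compound 3 differs from the core of compound 2 is not broken down here.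

Compound 4, `CN1CC[C@H](c2c(O)cc(O)c3c(=O)cc(/C=C/c4ccccc4Cl)oc23)[C@H](O)C1`, has not yet been measured. It differs from compound 3 by chloro in place of fluoro on an aromatic carbon. For the measured compounds named here, this is the same kind of change as the one from compound 2 to compound 1, though not the same: in compound 2 the place is also meta to a chloro group, which is not so in compound 3. Resting on the step of no change at the digits printed from compound 2 to compound 1 (within the scatter), where the same exchange made no difference on the other core, compound 4 is expected to sit close to compound 3, with an expected step of no change at the digits printed from compound 3 to compound 4 (within the scatter) in this assay. Going by the values given here, the estimate for compound 4 is 25%, expected to fall between 8% and 42%; only one earlier example of this exchange exists, and it sits on a different core, so the range is kept wide.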

Compound 4, percent growth inhibition at one concentration: 22%
Estimate against measurement, compound 4: 3 percentage points above; measured number inside the range.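

In this assay, chloro in place of fluoro on an aromatic carbon, here 2-fluorophenyl to 2-chlorophenyl, gives a number 3 percentage points lower from compound 3 to compound 4 (within the scatter), so on this second core too the exchange leaves the read-out within the scatter. Set beside the earlier case, the exchange carries over between the two cores without a measurable difference: the same change on two cores in this assay, no change at the digits printed (within the scatter) from compound 2 to compound 1 and a number 3 percentage points lower (within the scatter) from compound 3 to compound 4, 3 percentage points apart, within the scatter of two such steps. For the compounds shown here, this rests on only two pairs at a single concentration in one cell line, however, and the first pair is a weak test, since compound 1 gives 0% and compound 2 gives 0%, leaving no room on that core for the exchange to lower the number, so the agreement does not show that the two cores respond alike in general, nor does it explain why the exchange makes so little difference.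

The compounds shown leave open whether a bromo group, a methoxy group or a nitrile in the same place on the aromatic ring would also leave the read-out unchanged. They also leave open whether the exchange would stay just as silent on a compound with a much higher number in this assay, or at other concentrations.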